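The source may hold more compounds than are shown below. What is called first, only, known or untested is meant among the compounds shown, and "the series" means these compounds.

Measured so far in a functional assay on KB cells (Homo sapiens) for inhibition, read by sulforhodamine B assay; a higher number here means a weaker inhibitor of growth, a lower number a stronger inhibitor of growth:
- compound 1 `Cc1ccc2[nH]c(-c3ccc(-c4ccc(-c5ccc(N(C)C)cc5)cc4)cc3)nc2c1`: 6240 nM
- compound 2 `Fc1ccc(-c2ccc(-c3ccc(-c4nc5ccccc5[nH]4)cc3)cc2)cc1`: 41300 nM

Compound 2, at 41300 nM, holds the higher of the two numbers. Compound 1 sits lower at 6240 nM, a gap beyond the scatter.

Next in this assay is compound 3 `Cc1ccc2[nH]c(-c3ccc(-c4ccc(-c5ccc(F)cc5)cc4)cc3)nc2c1`, which is compound 2 with methyl in place of hydrogen on an aromatic carbon. For the measured compounds named here, no measured pair isolates this change. Compound 1, at 6240 nM, carries the same methyl but also differs from compound 2 in a second place, so it gives only a weak hint toward a lower number.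

A small move toward a lower number, within the scatter, is expected, estimated as a 1.6-fold lower number from compound 2 to compound 3 (0.20 log units; within the scatter). The estimate for compound 3 is 26000 nM, with an expected range of 9000 nM to 70000 nM.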

Compound 3, concentration for 50% growth inhibition: 24900 nM
Compound 3: the middle estimate sits 1.0-fold (0.02 log units) above what was measured; the measured number falls inside the stated range.
By their numbers in this assay, from the lowest: compound 1; then compounds 3 and 2 (each within the scatter of the next).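

In this assay, methyl in place of hydrogen on an aromatic carbon gives a 1.7-fold lower number from compound 2 to compound 3 (0.22 log units; within the scatter), so this position of the fused system accepts methyl with no shift that can be told from the scatter. Fluoro in place of dimethylamino on an aromatic carbon gives a 4.0-fold higher number from compound 1 to compound 3 (0.60 log units; beyond the scatter), which makes this exchange, with the methyl held constant, the only single change shown that moves the number beyond the scatter. Nothing at hand speaks to the reason for either step.

Whether the methyl step would hold alongside dimethylamino stays open, as the compounds shown offer no pair for it. Also open, going by these compounds, is how other groups would read at these two places, such as methoxy or chloro in place of the methyl, or a cyclic amine such as morpholine or a carboxylic acid in place of the fluoro.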